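Swapping the Urea-Bound Aryl Group in a Pyrazole Series

The source may report more compounds than this note shows. Statements on the series, on what has been measured and on what is new or still open speak of the compounds shown alone.

Of the compounds shown here, two that share one core have been measured in a functional assay on A549 cells (Homo sapiens) for inhibition, read by sulforhodamine B assay, with a stated time of 48 h, tested at 0.1 uM; on this read-out higher numbers stand for a weaker effect at the one concentration tested and lower numbers for a stronger effect. Compound 1, with the structure `COc1cc(Cl)cc(-c2nn(-c3cccc(NC(=O)Nc4ccc(Cl)c(C(F)(F)F)c4)c3)cc2-c2ccncc2)c1`, gives 98% in this assay. Compound 2, with the structure `COc1cc(Cl)cc(-c2nn(-c3cccc(NC(=O)Nc4ccc(Cl)c(Cl)c4)c3)cc2-c2ccncc2)c1`, gives 97% in this assay. Compound 2 stands as the lower of the two numbers, but its nearest neighbour is compound 1, and the step of a number 1 percentage points lower from compound 1 to compound 2 (within the scatter) shows that these two values cannot be told apart. Compound 3, with the structure `COc1cc(Cl)cc(-c2nn(-c3cccc(NC(=O)Nc4cccc(C(F)(F)F)c4)c3)cc2-c2ccncc2)c1`, has not yet been measured. It differs from compound 2 in one place: 3-(trifluoromethyl)phenyl in place of 3,4-dichlorophenyl on an amide-type nitrogen. Among the measured compounds shown here, the only measured step that bears on this change is the one from compound 1 to compound 2, where a chloro replaced a trifluoromethyl on an aromatic carbon with no effect beyond the scatter. The change to compound 3 undoes that swap and also removes one chloro from the same aryl group. With nothing in the measured values pointing either way, no step beyond the scatter is expected, so the step of a number 1 percentage points lower from compound 2 to compound 3 (within the scatter) is estimated to be small. Compound 3 is therefore expected to give about 96% in this assay, with a likely range from 86% to 100%.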

Compound 3, a percentage reported as activity, at one concentration (the size of the read-out at that concentration, not a potency): 96%
Compound 3: the middle estimate sits on the measured number at the digits printed; measured number inside the range.
By their numbers in this assay, from the lowest: compounds 3, 2 and 1 (each within the scatter of the next).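

Compound 3 tests more than the earlier exchange of one group for another on the aryl ring. The chloro of compound 1 is now replaced by plain hydrogen, and a number 2 percentage points lower from compound 1 to compound 3 (within the scatter) shows that in this assay this chloro can go without a change that can be told from the scatter. Exchanging the whole aryl group on the amide-type nitrogen, 3-(trifluoromethyl)phenyl in place of 3,4-dichlorophenyl, also gives no readable change, as a number 1 percentage points lower from compound 2 to compound 3 (within the scatter) shows, so the three aryl groups seen so far cannot be told apart at this one concentration. Nothing available gives a reason for these values, and no measurement here explains why they cannot be separated.

On these data alone, what a group of a different kind would do on this aryl ring stays open, for example an amine or a carboxylic acid, or a ring with no substituent at all. As far as these compounds go, it is also open whether these three compounds would separate at other concentrations, since a single-concentration read-out is not a potency, and whether changes to the shared core would matter more.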